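The source may report more compounds than this note shows. Statements on the series, on what has been measured and on what is new or still open speak of the compounds shown alone.

Compound 1 `CCC(CC)(c1nnc[nH]1)c1ccc(-c2ccc3cc(F)cc(F)c3c2)[nH]c1=O` gives 89 nM in an assay on CHO cells for displacement of a labelled ligand from prostaglandin E2 receptor EP3 subtype (Homo sapiens), read by radioligand binding; a higher number here means a weaker inhibitor, a lower number a stronger inhibitor.
Compound 2 `CCn1ncc2c(F)cc(-c3ccc(C(CC)(CC)c4nnc[nH]4)c(=O)[nH]3)cc21` gives 17 nM.
Compound 3 `CC(C)C(Cc1nnc[nH]1)c1ccc(-c2ccc3cccc(F)c3c2)[nH]c1=O` gives 10 nM.

In this assay compound 3 sits at the low end of the three numbers; its gap to compound 2 is within the usual scatter of repeated measurements, whereas compound 1 lies beyond it. Compound 4 `CC(C)C(c1ncc[nH]1)c1ccc(-c2ccc3cccc(F)c3c2)[nH]c1=O` has not yet been measured. It differs from compound 3 in one place: 1H-imidazol-2-yl in place of (4H-1,2,4-triazol-3-yl)methyl on a saturated chain carbon bound to an aromatic carbon and a saturated chain carbon. Within the data shown here, no measured pair isolates this change, so its effect is uncertain; compounds 1 and 2 carry their ring directly on the chain carbon, but both differ from compound 3 elsewhere as well. A modest weakening is expected, a 2.5-fold higher number from compound 3 to compound 4 (0.40 log units; beyond the scatter). Compound 4 is therefore estimated at 25 nM, with a range from 8 nM to 80 nM.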

Compound 4, inhibition constant: 7.3 nM
Beside the measured number, compound 4's estimate is 3.4-fold (0.53 log units) above it; the whole stated range lies above it.
By their numbers in this assay, from the lowest: compounds 4, 3 and 2 (each within the scatter of the next, the first and the last beyond it); then compound 1.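

In this assay the change at this saturated chain carbon gives a 1.4-fold lower number from compound 3 to compound 4 (0.14 log units; within the scatter) so the 1H-imidazol-2-yl and (4H-1,2,4-triazol-3-yl)methyl groups cannot be told apart here. This shows that, in this pair, the ring can change and the methyl link can go with no step beyond the scatter. Nothing available explains this result. Going by these compounds, the two alterations came together, so their separate contributions remain open, as would be tested by a 1H-imidazol-2-ylmethyl group. On these data alone, how a carboxylic acid or an amine would read at this place is also open.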